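The source may report more compounds than this note shows. Statements on the series, on what has been measured and on what is new or still open speak of the compounds shown alone.

Compound 1 `Cc1ccc(-c2nc(N)c3cc(Cc4ccccc4)sc3n2)o1`: 298 nM
Compound 2 `Cc1ccc(-c2nc(N)c3cc(CCc4ccccc4)sc3n2)o1`: 2780 nM
Compound 3 `COc1ccccc1Cc1cc2c(N)nc(-c3ccc(C)o3)nc2s1`: 122 nM

Of the compounds shown here, three sharing one core have been measured in a functional assay on CHO-K1 cells for antagonist activity at adenosine receptor A1 (Homo sapiens), read by a beta-galactosidase reporter and cAMP accumulation, with stated times of 15 min and 6 h; a lower number here means a stronger inhibitor, a higher number a weaker inhibitor. Compound 3 stands lowest of the three: the step of a 2.4-fold lower number from compound 1 to compound 3 (0.39 log units; beyond the scatter) and the step of a 23-fold lower number from compound 2 to compound 3 (1.36 log units; beyond the scatter) both lie beyond the scatter, so compound 3 is the strongest inhibitor of the group. The other measured step, a 9.3-fold higher number from compound 1 to compound 2 (0.97 log units; beyond the scatter), also concerns the substituent on the saturated chain carbon bound to an aromatic carbon.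

Compound 4 `COc1ccccc1Cc1cc2c(N)nc(-c3nc(C)cs3)nc2s1` keeps everything that distinguishes compound 3 and changes only the aromatic ring at the other end of the core: 4-methyl-1,3-thiazol-2-yl in place of 5-methylfuran-2-yl on an aromatic carbon. Within the data shown here, none of the measured steps touches this ring; all three involve the benzyl portion of the molecule. Among the measured compounds shown here, there is therefore no measured step that bears directly on the change from compound 3 to compound 4, and the expectation rests on the assumption that swapping one five-membered aromatic ring for another of the same size at this place leaves the number roughly where compound 3 put it. The estimated step of a 1.2-fold higher number from compound 3 to compound 4 (0.09 log units; within the scatter) is accordingly expected to fall within the scatter, with a wide range to reflect the lack of precedent. Compound 4 is estimated at 150 nM in this assay, between 40 nM and 600 nM.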

Compound 4, inhibition constant: 186 nM
Beside the measured number, compound 4's estimate is 1.2-fold (0.09 log units) below it, and the stated range covers the measured number.
By their numbers in this assay, from the lowest: compounds 3, 4 and 1 (each within the scatter of the next, the first and the last beyond it); then compound 2.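

In this assay the exchange on the aromatic carbon between two ring nitrogen atoms gives a 1.5-fold higher number from compound 3 to compound 4 (0.18 log units; within the scatter), so 5-methylfuran-2-yl and 4-methyl-1,3-thiazol-2-yl cannot be told apart in this measurement, even though the entering ring has 2 hetero atoms where the leaving ring has 1. Among these compounds, the earlier steps all concerned the benzyl portion of the molecule and all lay beyond the scatter, whereas this is the only step at the other end of the core, and it shows that, with the 2-methoxyphenyl portion held constant, this place tolerates the exchange of these two methyl-bearing five-membered aromatic rings. No measured evidence is available to account for the two rings reading alike.

The compounds shown leave open whether a six-membered ring such as phenyl or pyridin-2-yl, or a five-membered ring without its methyl group, would read the same at this place. They also leave open whether 4-methyl-1,3-thiazol-2-yl would match 5-methylfuran-2-yl when the methoxy group is replaced by hydrogen, as in compound 1, or when the longer chain of compound 2 is present.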